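A few compounds are considered here, and "the series" means these few. Any claim that something is new, unique, unknown or untested is made for them only; others in the source may bear on it.

Measured in a functional assay on A2780 cells (Homo sapiens) for inhibition, read by sulforhodamine B assay, with a stated time of 72 h; a higher number here means a weaker inhibitor, a lower number a stronger inhibitor:
- compound 1 `Cc1ccccc1S(=O)(=O)c1ccc(CNC(=O)c2cc3cnccc3[nH]2)cc1`: 13 nM
- compound 2 `O=C(NCc1ccc(S(=O)(=O)c2ccccc2)cc1)c1nc2cnccc2[nH]1`: 5400 nM
- compound 3 `O=C(Nc1ccc(S(=O)(=O)N2CCCCC2)cc1)c1cc2cnccc2[nH]1`: > 10000 nM, which is a limit of the assay and not a number

Compound 1 holds the lower of the two true numbers, and compound 2 lies far above it, well beyond the scatter.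

The next compound is compound 4 `O=C(NCc1ccc(S(=O)(=O)c2ccccc2C(F)(F)F)cc1)c1cc2cnccc2[nH]1`, which carries one change from compound 1: trifluoromethyl in place of methyl on an aromatic carbon. Here 2-methylphenyl becomes 2-(trifluoromethyl)phenyl. Going by the values given here, no measured pair shows what this swap does in this assay. Since the rest of the structure is unchanged, only a small rise from the 13 nM of compound 1 is expected, possibly none beyond the scatter. The expected change is a 1.9-fold higher number from compound 1 to compound 4 (0.28 log units; within the scatter). For compound 4 the estimated value is 25 nM, with an expected range of 6 nM to 100 nM.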

Compound 4, half-maximal inhibitory concentration: 25 nM
Beside the measured number, compound 4's estimate shows no gap at the digits printed; the range from low to high includes it.
By their numbers in this assay, from the lowest: compounds 1 and 4 (each within the scatter of the next); then compound 2. At a limit, above all of these: compound 3.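

In this assay, going by these compounds alone, the first pair at this position, trifluoromethyl in place of methyl on an aromatic carbon, ortho to a large group, gives a 1.9-fold higher number from compound 1 to compound 4 (0.28 log units; within the scatter). So this position accepts a group with more heavy atoms, and the two compounds cannot be told apart in this measurement. Nothing measured here explains why the two groups read alike. Still open is whether an amine or a carboxylic acid on this same carbon would fit as well, since both groups shown so far carry no hydrogen-bond donors or acceptors.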